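The source may report more compounds than this note shows. Statements on the series, on what has been measured and on what is new or still open speak of the compounds shown alone.

Measured so far:
Compound 1 `CC(C)=CCC1=C(OCc2cn(C3CCNCC3)nn2)C(=O)c2ccccc2C1=O`: 570000 nM
Compound 2 `CC(C)=CCC1=C(OCc2cn(-c3ccc(S(N)(=O)=O)cc3)nn2)C(=O)c2ccccc2C1=O`: 483000 nM

In an ADME assay on HepG2 cells (Homo sapiens) for cytotoxicity, read by MTT assay, with a stated time of 24 h (on this read-out lower numbers stand for higher toxicity in this test and higher numbers for lower toxicity in this test), compound 1 gives 570000 nM and compound 2 gives 483000 nM. The two numbers lie within the scatter of each other, so compound 2 stands level with compound 1 and nothing separates them. Going by the values given here, the only measured step, a 1.2-fold lower number from compound 1 to compound 2 (0.07 log units; within the scatter), exchanges the group on the aromatic nitrogen and changes nothing beyond the scatter.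

Compound 3 `COc1cc([N+](=O)[O-])ccc1-n1cc(COC2=C(CC=C(C)C)C(=O)c3ccccc3C2=O)nn1` differs from compound 2 by the change (2-methoxy-4-nitrophenyl in place of 4-sulfamoylphenyl on an aromatic nitrogen). Among the compounds with values here, this is again an exchange of the group on the same aromatic nitrogen, so the one step that bears on it is a 1.2-fold lower number from compound 1 to compound 2 (0.07 log units; within the scatter), which was flat. On that basis compound 3 is expected to show a step of a 1.0-fold higher number from compound 2 to compound 3 (0.02 log units; within the scatter) in this assay, that is, no change beyond the scatter. The estimate for compound 3 is 500000 nM, with a range from 250000 nM to 1000000 nM.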

Compound 3, half-maximal cytotoxic concentration: 701000 nM
Estimate against measurement, compound 3: 1.4-fold (0.15 log units) below; the measured number falls inside the stated range.
By their numbers in this assay, from the lowest: compounds 2, 1 and 3 (each within the scatter of the next).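

In this assay the third group on this aromatic nitrogen also stays within the scatter, with a 1.5-fold higher number from compound 2 to compound 3 (0.16 log units; within the scatter) and a 1.2-fold higher number from compound 1 to compound 3 (0.09 log units; within the scatter). The flat reading therefore no longer rests on a single exchange: it covers piperidin-4-yl, 4-sulfamoylphenyl and 2-methoxy-4-nitrophenyl, and it holds when a group with 1 hydrogen-bond donor gives way to one with 0 hydrogen-bond donors. No measurement is available that would account for these level numbers.

The compounds shown leave open whether a carboxylic acid, a simple methyl or an unsubstituted phenyl on this nitrogen would also stay level in this test. Going by these compounds, all three compounds keep the rest of the shared core unchanged, so it also remains open whether a longer chain or an amine elsewhere on that core would move the number.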